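A dichlorophenyl sulfonamide tested for cytotoxicity

The compounds below may be only part of what the source reports. "The series", "measured", "known", "first", "only" and "open" are said of these compounds alone.

Compound 1 `Cc1noc(C)c1S(=O)(=O)N1CCC(N2CCC(C)CC2)CC1` carries a 3,5-dimethyl-1,2-oxazol-4-yl group on its sulfonyl sulfur. In an ADME assay on HCT-116 cells (Homo sapiens) for cytotoxicity, read by CellTiter-Glo, with a stated time of 72 h (a lower number here means a stronger inhibitor, a higher number a weaker inhibitor), compound 1 gives only a limit, > 10000 nM, and so stands at the limit of > 10000 nM in this assay, at which 1 of the 3 values shown sits. Compound 2 `COc1ccc(-c2cccc(S(=O)(=O)N3CCC(N4CCC(C)CC4)CC3)c2)cc1` likewise reaches only a limit in this assay, > 5000 nM. Compound 3 `CC1CCN(C2CCN(C(=O)c3ccc(OC(F)(F)F)cc3)CC2)CC1`, an amide rather than a sulfonamide, also gives a limit in this assay, > 5000 nM. Compounds 2 and 3 thus share (the limit of > 5000 nM in this assay, at which 2 of the 3 values shown sit). Going by the values given here, none of the three shows measurable cytotoxicity, and no step between measured compounds is available. Compound 4 `CC1CCN(C2CCN(S(=O)(=O)c3ccc(Cl)cc3Cl)CC2)CC1` differs from compound 1 by 2,4-dichlorophenyl in place of 3,5-dimethyl-1,2-oxazol-4-yl on a sulfonyl sulfur. He expects at most a modest shift, an at least 1.2-fold lower number from compound 1 to compound 4 (0.09 log units; that floor lies within the scatter), not clearly beyond the scatter. For compound 4 in this assay the estimate is 8000 nM, between 3000 nM and 30000 nM, most likely again reported as a limit.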

Compound 4, half-maximal inhibitory concentration: > 5000 nM
Compound 4 ended at the assay's limit; the forecaster's own chance of this, stated with the estimate: 70%; the middle value lies beyond the limit too.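

Compound 1 and compound 4 both give only limits in this assay, so the step between them cannot be read. The compounds shown leave open whether any change on the sulfonyl sulfur would give a measurable value in this assay.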